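The compounds below may be only part of what the source reports. "The series", "measured", "known", "first", "only" and "open" are said of these compounds alone.

Compound 1 `COc1ccc(-c2cn3ccnc3c(-c3ccc4ncn(C5CCCCC5)c4c3)n2)cc1`: 91.7%
Compound 2 `c1ccc2c(-c3cn4ccnc4c(-c4ccc5ncn(C6CCCCC6)c5c4)n3)cccc2c1`: 6.92%
Compound 3 `Fc1ccc(-c2cn3ccnc3c(-c3ccc4ncn(C5CCCCC5)c4c3)n2)cc1`: 20.4%

The three compounds above were tested in a functional assay on SR cells (Homo sapiens) for inhibition, read by sulforhodamine B assay, with a stated time of 48 h, tested at 10 uM; a lower number here means less inhibition, a higher number more inhibition at the concentration tested (going by the name of the read-out). Compound 1 stands highest of the three, and the other two numbers lie far below it: the step of a number 84.8 percentage points lower from compound 1 to compound 2 (beyond the scatter) is large, and so is a number 71.3 percentage points lower from compound 1 to compound 3 (beyond the scatter). Between the two compounds with the lower numbers, a number 13.5 percentage points higher from compound 2 to compound 3 (beyond the scatter) is modest. The compound to be judged is compound 4 `COc1ccccc1-c1cn2ccnc2c(-c2ccc3ncn(C4CCCCC4)c3c2)n1`, which differs from compound 1 in a single group: 2-methoxyphenyl in place of 4-methoxyphenyl on an aromatic carbon. Going by the values given here, no measured step rearranges the methoxy group in this way; the two steps that start from compound 1 both replace the 4-methoxyphenyl with another group, and both cost a large share of the inhibition. They show that the read-out of compound 1 is sensitive to what sits at this place, but they do not show whether a 2-methoxyphenyl gives a higher, a lower or a level number. Compound 4 is therefore expected to fall below compound 1, with a step of a number 46.7 percentage points lower from compound 1 to compound 4 (beyond the scatter), though with wide uncertainty. The estimate for compound 4 is 45%, within the range 10% to 88%.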

Compound 4, a percentage reported as inhibition, at one concentration (the size of the read-out at that concentration, not a potency): 26.3%
For compound 4 the middle estimate is 18.7 percentage points above the measured one; low and high end bracket the measured number.
By their numbers in this assay, from the lowest: compound 2; then compounds 3 and 4 (each within the scatter of the next); then compound 1.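

Moving the methoxy group within the same phenyl ring, with no change in atoms or in the counts of donors and acceptors, is enough to remove most of the inhibition in this assay: 2-methoxyphenyl in place of 4-methoxyphenyl gives a number 65.4 percentage points lower from compound 1 to compound 4 (beyond the scatter), so the presence of a methoxy group at this place does not by itself carry the high number. Set against the other two groups, 2-methoxyphenyl in place of 4-fluorophenyl gives a number 5.9 percentage points higher from compound 3 to compound 4 (within the scatter), while 2-methoxyphenyl in place of naphthalen-1-yl gives a number 19.4 percentage points higher from compound 2 to compound 4 (beyond the scatter), leaving the 4-methoxyphenyl of compound 1 as the only group shown here that gives a high number. The data shown offer no measurement that explains the loss on moving the methoxy group.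

On these data alone, it remains open whether a hydroxyl, an amine or a longer chain such as ethoxy, put in place of the methoxy of the 4-methoxyphenyl group, would keep the inhibition seen for compound 1. Also open, as far as these compounds go, is whether the same order would hold if the cyclohexyl group were replaced by a smaller chain or a piperidine, since all four compounds carry the cyclohexyl group.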